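One Methyl Added to Compound 2

This account rests on a few compounds, and the source may have more. Where it says the series, first, only, none or still open, it means among the compounds named here.

Within the data shown here, in a functional assay (Platelet, plasma) for inhibition, with Homo sapiens as the target (on this read-out higher numbers stand for weaker inhibition and lower numbers for stronger inhibition), compound 2 (`N#Cc1cc2c(nc1N1CCC(C(=O)NS(=O)(=O)Cc3ccc(F)cc3F)CC1)COC2=O`) gives 5200 nM as the higher of the two known numbers. The gap to compound 1 (`CC1(C(=O)NS(=O)(=O)c2ccc(Cl)s2)CCN(c2nc3c(cc2C#N)C(=O)OC3)CC1`) at 1640 nM lies beyond the scatter. Compound 3 (`CC1(C(=O)NS(=O)(=O)Cc2ccc(F)cc2F)CCN(c2nc3c(cc2C#N)C(=O)OC3)CC1`) has methyl in place of hydrogen on a saturated ring carbon of compound 2 (methyl in place of hydrogen on a saturated ring carbon). Among the measured compounds shown here, no measured pair isolates this change, and compound 1 carries a methyl but also differs elsewhere. In this assay only a small move toward stronger inhibition is expected, possibly none beyond the scatter. The expected step is a 1.5-fold lower number from compound 2 to compound 3 (0.17 log units; within the scatter) in size. Compound 3 is estimated at 3500 nM (range 1200 nM to 10000 nM).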

Compound 3, half-maximal inhibitory concentration: 8760 nM
The estimate for compound 3 lay 2.5-fold (0.40 log units) below the measured number; measured number inside the range.
By their numbers in this assay, from the lowest: compound 1; then compounds 2 and 3 (each within the scatter of the next).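

Methyl in place of hydrogen on a saturated ring carbon gives a 1.7-fold higher number from compound 2 to compound 3 (0.23 log units; within the scatter) in this assay and so this ring position takes the methyl without a shift beyond the scatter. With the methyl kept, 2,4-difluorobenzyl in place of 5-chlorothiophen-2-yl on a sulfonyl sulfur gives a 5.3-fold higher number from compound 1 to compound 3 (0.73 log units; beyond the scatter) and that step, unlike the methyl step, lies beyond the scatter. On these data alone, whether an ethyl or a hydroxyl on this ring carbon would read like the methyl stays open, as does the 5-chlorothiophen-2-yl group with hydrogen restored there. No measurement at hand accounts for either step.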